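This account rests on a few compounds, and the source may have more. Where it says the series, first, only, none or still open, it means among the compounds named here.

Working notes on the series. Of the compounds shown here, three have been measured in a functional assay on NCI-H460 cells (Homo sapiens) for inhibition, read by MTT assay, with a stated time of 72 h; on this read-out higher numbers stand for weaker inhibition and lower numbers for stronger inhibition. Compound 1 `CN(C)CCn1c(=O)c(=Cc2ccc(F)c(F)c2)s/c1=C1\C(=O)Nc2cc(F)ccc21` gives 6400 nM in this assay. Compound 2 `CCN(CC)CCCn1c(=O)c(=Cc2ccc(F)c(F)c2)s/c1=C1\C(=O)Nc2cc(F)ccc21` gives 1120 nM, and compound 3 `CCN(CC)CCCn1c(=O)c(=Cc2ccc(F)c(F)c2)s/c1=C1\C(=O)Nc2ccc(F)cc21` gives 1300 nM. Compound 2 stands lowest of the three numbers, but its gap to compound 3 is within the scatter, so no order between those two is claimed; only compound 1 is set apart, and the step of a 5.7-fold lower number from compound 1 to compound 2 (0.76 log units; beyond the scatter) shows how far.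

Compound 4 `CCN(CC)CCCn1c(=O)c(=Cc2ccc(F)cc2F)s/c1=C1\C(=O)Nc2cc(F)ccc21` is not yet measured. It differs from compound 2 only in the aryl group on the exocyclic carbon: 2,4-difluorophenyl in place of 3,4-difluorophenyl on a double-bonded chain carbon bound to an aromatic carbon. Among the measured compounds shown here, none of the measured steps touches this position; the one step that is quantified, a 5.7-fold lower number from compound 1 to compound 2 (0.76 log units; beyond the scatter), concerns the amine on the side chain, and the pair compound 2 and compound 3 concerns the fluorine on the shared core. For the measured compounds named here, no step bearing on the aryl fluorine pattern exists in the data, so the expectation rests on compound 2 alone. A step of a 1.3-fold higher number from compound 2 to compound 4 (0.10 log units; within the scatter) is expected, which is to say no change beyond the scatter. Compound 4 is therefore estimated at 1400 nM in this assay, within a range of 500 nM to 4000 nM.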

Compound 4, half-maximal inhibitory concentration: 2330 nM
The estimate for compound 4 lay 1.7-fold (0.22 log units) below the measured number; low and high end bracket the measured number.
By their numbers in this assay, from the lowest: compounds 2, 3 and 4 (each within the scatter of the next, the first and the last beyond it); then compound 1.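

In this assay, among the compounds shown here, the step of a 2.1-fold higher number from compound 2 to compound 4 (0.32 log units; beyond the scatter) is the first reading at the aryl group on a double-bonded chain carbon bound to an aromatic carbon, and it shows that this position responds to the fluorine pattern, though the step is modest. The 3,4-difluorophenyl and 2,4-difluorophenyl groups have the same atoms and the same single aromatic ring of carbon only, with no hydrogen-bond donors or acceptors and no net charge on either side, so a rearrangement of the same atoms alone is enough to move the number beyond the scatter. Nothing measured here accounts for the direction of this step.

The compounds shown leave open how unsubstituted phenyl, 4-fluorophenyl or 3,4-dichlorophenyl would compare with 3,4-difluorophenyl at this position, so the reading rests on a single pair of fluorine patterns. They also leave open whether the step would keep its size with the dimethylamino side chain of compound 1 or with the core of compound 3, since the aryl change is seen only against compound 2.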